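Compound 3 to compound 4: a fluoro swap at the limit

The source may hold more compounds than are shown below. What is called first, only, known or untested is meant among the compounds shown, and "the series" means these compounds.

In an ADME assay on MRC5 cells (Homo sapiens) for cytotoxicity, read by fluorescence, with a stated time of 72 h (on this read-out lower numbers stand for stronger inhibition and higher numbers for weaker inhibition), compound 1 (`CC1(COc2ccc(-c3ccc(F)cc3)cc2)Cn2cc([N+](=O)[O-])nc2O1`) reads > 64000 nM as a limit. Compound 2 (`CC1(COc2ccc(Oc3ccccc3)cc2)Cn2cc([N+](=O)[O-])nc2O1`) reads > 64000 nM as a limit too. Compound 3 (`O=[N+]([O-])c1cn2c(n1)OC(COc1ccc(-c3ccc(F)cc3)cc1)C2`) reads > 64000 nM as a limit as well, so it has no numerical place in the series. All three readings sit at one mark (the limit of > 64000 nM in this assay, at which 3 of the 3 values shown sit).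

Compound 4 (`O=[N+]([O-])c1cn2c(n1)OC(COc1ccc(-c3ccc(OC(F)(F)F)cc3)cc1)C2`) carries trifluoromethoxy in place of fluoro on an aromatic carbon of a six-membered aromatic ring of carbon only, para to a large group (trifluoromethoxy in place of fluoro on an aromatic carbon).

Within the data shown here, two measured steps bear on this change. One is phenoxy in place of 4-fluorophenyl on an aromatic carbon (a step that the two limits leave unreadable from compound 1 to compound 2), and the other is hydrogen in place of methyl on a saturated ring carbon (a step that the two limits leave unreadable from compound 1 to compound 3). Neither size can be read, so neither offers a measured size or direction to carry over.

The expectation for compound 4 therefore leans on compound 3 with its limit of > 64000 nM as the only anchor. In this assay no step beyond the scatter is expected, and the estimated step is an at least 1.0-fold lower number from compound 3 to compound 4 (0.02 log units; that floor lies within the scatter) in this reading. A result at the same limit is the likeliest outcome. Compound 4 is estimated at 60000 nM with an expected range of 30000 nM to 64000 nM in this assay.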

Compound 4, half-maximal inhibitory concentration: > 64000 nM
Compound 4: a limit, no number (the forecaster's own chance of this, stated with the estimate: 80%); middle value at least 1.0-fold (0.02 log units) from the limit.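

In this assay compound 4 gives > 64000 nM, which is a limit and not a number. Among these compounds, compound 3 also stands at a limit, so no step between compound 3 and compound 4 can be read. The compounds shown leave open whether any change among them shifts this read-out, as every reading stands at one mark: the limit of > 64000 nM in this assay, at which 4 of the 4 values shown sit.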